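Fluoro for Methoxy on a Lightly Explored Scaffold

A few compounds are considered here, and "the series" means these few. Any claim that something is new, unique, unknown or untested is made for them only; others in the source may bear on it.

Among the measured compounds shown here, in an ADME assay on Vero cells (Chlorocebus sabaeus) for inhibition (on this read-out lower numbers stand for higher toxicity in this test and higher numbers for lower toxicity in this test), compound 1 (`COc1ccc(/C=C2\CCC/C(=C\c3ccc(OC)cc3)C2=O)cc1`) gives 178000 nM and stands highest of the two numbers so far. Compound 2 (`O=C1/C(=C/c2ccc(Cl)cc2)CCC/C1=C\c1ccc(Cl)cc1`) gives 32100 nM and is its nearest neighbour, lower by more than the scatter. Compound 3 (`COc1ccc(/C=C2\CCC/C(=C\c3ccc(F)cc3)C2=O)cc1`) has fluoro in place of methoxy on an aromatic carbon, para to a large group (fluoro in place of methoxy on an aromatic carbon). For the measured compounds named here, no step changing a single place has been measured, so the only guide is compound 2 at 32100 nM and it carries no methoxy. A modest downward move is expected, namely a 2.2-fold lower number from compound 1 to compound 3 (0.35 log units; beyond the scatter) as estimated here. Compound 3 is estimated at 80000 nM (range 32000 nM to 190000 nM).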

Compound 3, half-maximal cytotoxic concentration: 378000 nM
Compound 3: the middle estimate sits 4.7-fold (0.67 log units) below what was measured, and the stated range ends below it.
By their numbers in this assay, from the lowest: compound 2; then compound 1; then compound 3.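

In this assay, among the compounds shown here, the step from 4-methoxyphenyl to 4-fluorophenyl gives a 2.1-fold higher number from compound 1 to compound 3 (0.33 log units; beyond the scatter) and is the first change at a single place that can be read on its own. At this position, losing one methoxy for fluoro therefore moves the number up, towards lower toxicity in this test. Nothing measured here explains that direction.

Going by these compounds, whether an amine or a hydroxyl at the same place would move the number further remains open. So does whether the step repeats when the second methoxy of compound 1 is exchanged as well.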